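The source may report more compounds than this note shows. Statements on the series, on what has been measured and on what is new or still open speak of the compounds shown alone.

- Compound 1 `O=C(O)CCNC(=O)c1ccc2c(c1)C(=O)N(CCC1CCNCC1)C2`: 27 nM
- Compound 2 `CCOCCS(=O)(=O)N[C@@H](CNC(=O)c1ccc2c(c1)C(=O)N(CCC1CCNCC1)C2)C(=O)O`: 8 nM
- Compound 3 `CCCCNS(=O)(=O)N[C@@H](CNC(=O)c1ccc2c(c1)C(=O)N(CCC1CCNCC1)C2)C(=O)O`: not yet measured

In a functional assay for inhibition, with Homo sapiens as the target (on this read-out lower numbers stand for stronger inhibition and higher numbers for weaker inhibition), compound 2 has the lower of the two numbers, 8 nM, while compound 1 stands at 27 nM. Compound 3 keeps the rest of compound 2 and puts butylamino in place of 2-ethoxyethyl on a sulfonyl sulfur.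

For the measured compounds named here, only one measured step bears on this change, and only indirectly: a 3.4-fold lower number from compound 1 to compound 2 (0.53 log units; beyond the scatter). Going by the values given here, that step brought in the whole ((2-ethoxyethyl)sulfonyl)amino group, and no measured pair varies what sits on the sulfonyl sulfur. The data therefore point in neither direction, and no step beyond the scatter is expected in this assay. The expected step is no change at the digits printed from compound 2 to compound 3 (within the scatter). For compound 3 the estimated value is 8 nM, with an expected range of 3 nM to 22 nM.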

Compound 3, half-maximal inhibitory concentration: 19 nM
Compound 3: middle estimate off by 2.4-fold (0.38 log units), on the low side; measured number inside the range.
By their numbers in this assay, from the lowest: compound 2; then compounds 3 and 1 (each within the scatter of the next).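

In this assay, for the compounds shown here, the group on the sulfonyl sulfur proves to count: butylamino in place of 2-ethoxyethyl gives a 2.4-fold higher number from compound 2 to compound 3 (0.38 log units; beyond the scatter) and so shows a measured difference at this place, which the earlier compounds could not show. The added group also no longer gives a step beyond the scatter when it is the butylsulfamoyl form, with a 1.4-fold lower number from compound 1 to compound 3 (0.15 log units; within the scatter) against the larger step seen for the ((2-ethoxyethyl)sulfonyl)amino group, so the earlier step does not hold for every group of this kind. Nothing measured here accounts for the difference between butylamino and 2-ethoxyethyl.

The two groups differ both in the oxygen of the chain and in the nitrogen on the sulfur, and the compounds shown do not separate these two changes. A butyl group or a 2-ethoxyethylamino group on the same sulfur would pull them apart.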